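From Methyl to Isopropyl on an Aromatic Carbon

A few compounds are considered here, and "the series" means these few. Any claim that something is new, unique, unknown or untested is made for them only; others in the source may bear on it.

Compound 1 `Nc1ccccc1NC(=O)c1ccc(COc2ccccc2)cc1`: 5670 nM
Compound 2 `Cc1ccc(OCc2ccc(C(=O)Nc3ccccc3N)cc2)cc1`: 6530 nM

These two compounds were measured in a functional assay on MGC-803 cells (Homo sapiens) for antiproliferative activity, read by CCK-8 assay, with a stated time of 72 h; a lower number here means a stronger inhibitor, a higher number a weaker inhibitor. Going by the values given here, compound 2, at 6530 nM, lies within the scatter of compound 1, the only other measured compound, so the pair sets no order. The next compound, compound 3 `CC(C)c1ccc(OCc2ccc(C(=O)Nc3ccccc3N)cc2)cc1`, differs from compound 2 at one place: isopropyl in place of methyl on an aromatic carbon. This is isopropyl in place of methyl on an aromatic carbon, para to a large group.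

Among the compounds with values here, one measured step bears on this change: a 1.2-fold higher number from compound 1 to compound 2 (0.06 log units; within the scatter). It is the replacement of hydrogen by methyl on an aromatic carbon. Within the data shown here, that single step offers thin evidence, and no measured compound shows how a group larger than methyl behaves. Among the measured compounds shown here, with only the step to compound 2 as a guide, no shift beyond the scatter is expected in this assay, and no direction is favoured. The expected step is a 1.0-fold lower number from compound 2 to compound 3 (0.00 log units; within the scatter). Compound 3 is estimated at 6500 nM, with an expected range from 3000 nM to 14000 nM.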

Compound 3, half-maximal inhibitory concentration: > 32000 nM
Compound 3: a limit, no number; the forecaster's own chance of this, stated with the estimate: 3%; at least 4.9-fold (0.69 log units) between middle value and limit.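

The aromatic carbon para to a large group proves not to be indifferent to what it carries: in this assay, hydrogen and methyl could not be told apart, yet isopropyl in place of methyl gives an at least 4.9-fold higher number from compound 2 to compound 3 (0.69 log units; beyond the scatter). Set against hydrogen, the same group gives an at least 5.6-fold higher number from compound 1 to compound 3 (0.75 log units; beyond the scatter), so both steps point towards weaker activity and both lie beyond the scatter. The value of compound 3 is a limit of the assay and not a number: the limit of > 32000 nM in this assay, at which 1 of the 3 values shown sits.

The compounds shown do not say why isopropyl differs from methyl here, nor whether the loss of activity grows gradually with the size of the carbon group or sets in abruptly, a question that ethyl on the same carbon would address. They also leave open whether the loss belongs to branched carbon groups alone or extends to other groups at this place, such as a methoxy group, a chlorine atom or an amine.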